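Compound 2 to compound 3: acetyl for phenethyl

The source may hold more compounds than are shown below. What is called first, only, known or untested is meant among the compounds shown, and "the series" means these compounds.

Values in an ADME assay on MT4 cells (Homo sapiens) for cytotoxicity, read by MTT assay; on this read-out higher numbers stand for lower toxicity in this test and lower numbers for higher toxicity in this test:
Compound 1 `O=c1cc(Cc2c(F)cccc2F)nc(SCc2c(F)cccc2F)[nH]1`: > 66000 nM
Compound 2 `O=c1cc(Cc2c(F)cccc2F)nc(SCCCc2ccccc2)[nH]1`: 32000 nM

Compound 1 gives > 66000 nM, and this is a limit of the assay, not a number. Among the compounds with values here, compound 2 therefore holds the only actual number in this assay, 32000 nM.

Compound 3 `CC(=O)CSc1nc(Cc2c(F)cccc2F)cc(=O)[nH]1` is not yet measured. It carries acetyl in place of phenethyl on a saturated chain carbon bound to a sulfur.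

Within the data shown here, one measured step bears on this change: an at least 2.0-fold lower number from compound 1 to compound 2 (0.31 log units; beyond the scatter). That step brought phenethyl in, and compound 3 loses it again, although acetyl is not the group that phenethyl replaced there. A move to a higher number is therefore expected, of uncertain size. The estimated step is a 2.3-fold higher number from compound 2 to compound 3 (0.37 log units; beyond the scatter). For compound 3 the expected value is 75000 nM, with an estimated range of 28000 nM to 220000 nM.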

Compound 3, half-maximal cytotoxic concentration: > 81000 nM
Compound 3 ended at the assay's limit; the forecaster's own chance of this, stated with the estimate: 45%; middle value at least 1.0-fold (0.03 log units) away from the limit.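

In this assay, the change from phenethyl to acetyl gives an at least 2.5-fold higher number from compound 2 to compound 3 (0.40 log units; beyond the scatter). Compound 3 gives > 81000 nM, which is a limit of the assay and not a number. Among the three groups shown on this saturated chain carbon bound to a sulfur, only phenethyl gives an actual number, while 2,6-difluorophenyl and acetyl, one with an aromatic ring and one without, both end at a limit, and the step between compound 1 and compound 3 cannot be read.

Going by these compounds, it stays open whether the lower number with phenethyl follows from its chain or from its unsubstituted phenyl ring, a question that a butyl chain or an unsubstituted phenyl at this place would address. Whether an amine or a carboxylic acid here would also end at a limit is open too.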